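Swapping the Silicon Group on a Shared Lactone Core

The source may hold more compounds than are shown below. What is called first, only, known or untested is meant among the compounds shown, and "the series" means these compounds.

Compound 1 `C=C1CC[C@@H]2[C@](C)(CO[Si](c3ccccc3)(c3ccccc3)C(C)(C)C)[C@H](OC(C)=O)CC[C@@]2(C)[C@@H]1C/C=C1/C(=O)OC[C@H]1O`: 9.86 uM
Compound 2 `C=C1CC[C@@H]2[C@](C)(CO[Si](C(C)C)(C(C)C)C(C)C)[C@H](OC(C)=O)CC[C@@]2(C)[C@@H]1C/C=C1/C(=O)OC[C@H]1OC(C)=O`: 7.39 uM
Compound 3 `C=C1CC[C@@H]2[C@](C)(CO)[C@H](OC(C)=O)CC[C@@]2(C)[C@@H]1C/C=C1/C(=O)OC[C@H]1O`: 35.7 uM

Of the compounds shown here, three built on the same core have been tested in a functional assay on KB cells (Homo sapiens) for cytotoxicity, read by sulforhodamine B assay; on this read-out lower numbers stand for an effect already at smaller amounts and higher numbers for an effect only at larger amounts of compound. Compound 2 gives 7.39 uM in this assay, and compound 1 gives 9.86 uM, a number that sits within the usual scatter of compound 2, so the two cannot be told apart. Compound 3, which carries a free hydroxyl where the other two carry a silicon-containing group, gives 35.7 uM, and the gap between this number and that of compound 2 lies beyond the scatter.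

Compound 4 `C=C1CC[C@@H]2[C@](C)(CO[Si](C)(C)C(C)(C)C)[C@H](OC(C)=O)CC[C@@]2(C)[C@@H]1C/C=C1/C(=O)OC[C@H]1OC(C)=O` has not yet been measured. It differs from compound 2 in one place: a group of 7 heavy atoms (6 carbon, 1 silicon; no ring) in place of a group of 10 heavy atoms (9 carbon, 1 silicon; no ring), on an oxygen on a saturated carbon. The silicon-containing group stays in place and only its size changes. Since compound 1 and compound 2, which carry two different silicon-containing groups, give numbers within the scatter of each other, the step from compound 2 to compound 4 is expected to be small, with no direction that can be read beyond the scatter; the expected step is a 1.2-fold higher number from compound 2 to compound 4 (0.09 log units; within the scatter). Compound 4 is therefore estimated at 9 uM in this assay, within a range from 4 uM to 20 uM.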

Compound 4, concentration for half-maximal effect: 3.62 uM
Estimate against measurement, compound 4: 2.5-fold (0.40 log units) above; measured number below the stated range.
By their numbers in this assay, from the lowest: compound 4; then compounds 2 and 1 (each within the scatter of the next); then compound 3.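

In this assay, the group on this oxygen on a saturated carbon does affect the read-out: replacing the group of 10 heavy atoms with the group of 7 heavy atoms gives a 2.0-fold lower number from compound 2 to compound 4 (0.31 log units; beyond the scatter), a small step that still clears the usual scatter. The earlier compounds shown here could not show this, since the silicon-containing groups of compound 1 and compound 2 come with a second difference, a free hydroxyl in compound 1 where compound 2 carries an acetyl ester, whereas compound 2 and compound 4 differ in this one place alone. This single pair links the smaller group to the lower number, but it makes no trend, and nothing available here explains the step.

Still open, from the compounds shown here alone, is whether the numbers would keep moving in this direction with a trimethylsilyl group on the same oxygen, or what a group without silicon, such as a methyl or benzyl ether, would give. Also open, going by these compounds, is whether the same swap would give a similar step with the free hydroxyl of compound 1 in place of the acetyl ester.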